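Swapping an aromatic arm for a small ring at the receptor

A few compounds are considered here, and "the series" means these few. Any claim that something is new, unique, unknown or untested is made for them only; others in the source may bear on it.

Measured compounds:
compound 1, `CCCCc1cnc(C(CCCO)Cc2ccc(-c3ccccc3C(=O)O)cc2)[nH]1`, 238 nM
compound 2, `COc1ccccc1Cc1cnc(CCc2ccc(-c3ccccc3C(=O)O)cc2)[nH]1`, 163 nM

Both were tested in an in vitro functional assay on cells for agonist activity at Bombesin receptor subtype-3 (Mus musculus), read by luminescence and calcium flux; on this read-out lower numbers stand for an effect already at smaller amounts and higher numbers for an effect only at larger amounts of compound. Compound 2 gives a number close to that of compound 1, inside the usual scatter, so the two cannot be told apart. Compound 3, `O=C(O)c1ccccc1-c1ccc(CCc2ncc(CC3CCCC3)[nH]2)cc1`, has not been tested. It differs from compound 2 by cyclopentyl in place of 2-methoxyphenyl on a saturated chain carbon bound to an aromatic carbon. Going by the values given here, no measured pair shows this kind of swap, so no step size is known. Compound 3 is expected to give a number somewhat higher, by a 2.1-fold higher number from compound 2 to compound 3 (0.33 log units; beyond the scatter), around 350 nM, with a range from 100 nM to 1200 nM.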

Compound 3, half-maximal effective concentration: 7.9 nM
Compound 3: the middle estimate sits 44-fold (1.65 log units) above what was measured, outside the stated range (below it).
By their numbers in this assay, from the lowest: compound 3; then compounds 2 and 1 (each within the scatter of the next).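

At this place, on a saturated chain carbon bound to an aromatic carbon, the choice of ring matters greatly: in this assay, cyclopentyl in place of 2-methoxyphenyl gives a 21-fold lower number from compound 2 to compound 3 (1.31 log units; beyond the scatter). An aromatic ring is therefore not needed here, and a smaller ring of carbon only, without the hydrogen-bond acceptor, does better. Nothing available explains this gain. The swap changes the ring and removes the methoxy group together, so the compounds shown leave open which of the two matters, and whether plain phenyl or cyclohexyl would match cyclopentyl.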